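The source may report more compounds than this note shows. Statements on the series, on what has been measured and on what is new or still open speak of the compounds shown alone.

Measured so far in a functional assay on NCI-H1975 cells (Homo sapiens) for antiproliferative activity, read by MTT assay, with a stated time of 72 h; on this read-out lower numbers stand for stronger inhibition and higher numbers for weaker inhibition:

Compound 1, `COc1cc2ncnc(Nc3cccc(Br)c3)c2cc1OCCCCC(=O)Nc1ccc(S(N)(=O)=O)cc1`, gives 11400 nM.
Compound 2, `COc1cc2ncnc(Nc3ccc(F)c(Br)c3)c2cc1OCCCCC(=O)Nc1ccc(S(N)(=O)=O)cc1`, gives 31600 nM.
Compound 3, `NS(=O)(=O)c1ccc(NC(=S)Nc2ccc3ncnc(Nc4ccc(F)c(Br)c4)c3c2)cc1`, gives 9980 nM.

Compounds 1 and 2 share one core and differ in a single place: hydrogen in place of fluoro on an aromatic carbon. This change produced a 2.8-fold lower number from compound 2 to compound 1 (0.44 log units; beyond the scatter). Compound 3 is built on a different core, and the difference between the two cores is not broken down here; what can be said is that compound 3 and compound 1 give numbers that lie within the scatter of each other, while compound 2 sits beyond it.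

Compound 4, `NS(=O)(=O)c1ccc(NC(=S)Nc2ccc3ncnc(Nc4cccc(Br)c4)c3c2)cc1`, carries the core of compound 3 with the same change already seen between compound 2 and compound 1: hydrogen in place of fluoro on an aromatic carbon. The surroundings of the change are described in the same words for both pairs, so it is the same change on a different core. Within the data shown here, because a 2.8-fold lower number from compound 2 to compound 1 (0.44 log units; beyond the scatter) pointed toward a lower number, a step in the same direction is expected here, though a somewhat smaller one is estimated, since only one earlier example exists: a 2.0-fold lower number from compound 3 to compound 4 (0.30 log units; within the scatter). Compound 4 is therefore expected to give 5000 nM, with a plausible range of 2500 nM to 12000 nM.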

Compound 4, half-maximal inhibitory concentration: 11000 nM
Compound 4: the middle estimate sits 2.2-fold (0.34 log units) below what was measured; measured number inside the range.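

On the core of compound 3, going from the 3-bromo-4-fluorophenyl group to the 3-bromophenyl group in this assay gives a 1.1-fold higher number from compound 3 to compound 4 (0.04 log units; within the scatter), so this pair shows no readable effect of the change. Set beside the earlier pair, the same swap of fluoro for hydrogen does not carry over with the same size from one core to the other: the same change on two cores in this assay, a 2.8-fold lower number (0.44 log units; beyond the scatter) from compound 2 to compound 1 and a 1.1-fold higher number (0.04 log units; within the scatter) from compound 3 to compound 4, 3.1-fold (0.49 log units) apart, beyond the scatter of two such steps This shows that, in these two pairs, the step seen on one core could not have been simply transferred to the other, but it does not show which difference between the cores is responsible, and two pairs make no general rule.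

The compounds shown leave open how a chloro or a methyl group in place of the fluoro would read on either core. They also leave open whether the change would behave the same way on the core of compound 1 with a shorter or longer chain.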